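Compound 2 and the step to a bromine-bearing compound 3

This account rests on a few compounds, and the source may have more. Where it says the series, first, only, none or still open, it means among the compounds named here.

Compound 1 `O=C(/C=C/c1cccc(OCc2ccccc2)c1)c1ccc([N+](=O)[O-])cc1`: 59300 nM
Compound 2 `Cc1ccc(C(=O)/C=C/c2cccc(OCc3ccccc3)c2)cc1`: 8200 nM

In an ADME assay on HEK293 cells (Homo sapiens) for cytotoxicity, read by MTT assay, with a stated time of 68 h (a higher number here means a weaker inhibitor, a lower number a stronger inhibitor), compound 2 has the lower of the two measured numbers, 8200 nM. The next compound to be measured is compound 3 `O=C(/C=C/c1cccc(OCc2ccccc2)c1)c1cccc(Br)c1`, which has 3-bromophenyl in place of 4-methylphenyl on a carbonyl carbon. Among the compounds with values here, only one measured step offers any guide: a 7.2-fold lower number from compound 1 to compound 2 (0.86 log units; beyond the scatter), which came with methyl in place of nitro on an aromatic carbon. That guide is loose, as neither compound in that step carries bromine. Its size is therefore an outer reference, not a forecast. In this assay a smaller change toward a higher number is expected, estimated as a 1.6-fold higher number from compound 2 to compound 3 (0.20 log units; within the scatter). For compound 3 the estimated value is 13000 nM, with an expected range from 4500 nM to 38000 nM.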

Compound 3, half-maximal inhibitory concentration: 7100 nM
The estimate for compound 3 lay 1.8-fold (0.26 log units) above the measured number; the range from low to high includes it.
By their numbers in this assay, from the lowest: compounds 3 and 2 (each within the scatter of the next); then compound 1.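

In this assay, 3-bromophenyl in place of 4-methylphenyl on a carbonyl carbon gives a 1.2-fold lower number from compound 2 to compound 3 (0.06 log units; within the scatter), so two groups that differ in both their substituent and its place on the ring cannot be told apart here. Measured against the nitro-bearing compound, the new group gives an 8.4-fold lower number from compound 1 to compound 3 (0.92 log units; beyond the scatter), which shows that the earlier 7.2-fold lower number from compound 1 to compound 2 (0.86 log units; beyond the scatter) was not unique to methyl: compound 1 now stands apart from two compounds rather than one. Nothing available explains why these groups read as they do.

Going by these compounds, this single step changes the substituent and its place together, so the effect of each alone remains unknown. On these data alone, how an amine or a carboxylic acid on this ring would read in this assay also remains open.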